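The source may report more compounds than this note shows. Statements on the series, on what has been measured and on what is new or still open speak of the compounds shown alone.

Measured so far in an ADME assay on MT4 cells (Homo sapiens) for cytotoxicity, read by MTT assay, with a stated time of 5 days; on this read-out lower numbers stand for higher toxicity in this test and higher numbers for lower toxicity in this test:
- compound 1 `CN(C)c1ccnc(Nc2ccc(C#N)cc2)n1`: 34000 nM
- compound 2 `N#Cc1ccc(Nc2nccc(OCc3ccccc3Br)n2)cc1`: 130000 nM
- compound 3 `N#Cc1ccc(Nc2nccc(OCc3ccccc3F)n2)cc1`: 151000 nM

Not yet measured: compound 4 `Cc1ccccc1COc1ccnc(Nc2ccc(C#N)cc2)n1`.

Compound 2, at 130000 nM, lies within the scatter of compound 3, and the two sit clearly on the high side of compound 1, which gives 34000 nM. On this read-out, that places compound 2 among the less toxic of the three.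

The next step replaces the 2-bromobenzyl group of compound 2 with 2-methylbenzyl to give compound 4. This puts methyl in place of bromo on an aromatic carbon, ortho to a large group: methyl in place of bromo on an aromatic carbon.

Within the data shown here, one measured step bears on this change, at the same place: a 1.2-fold higher number from compound 2 to compound 3 (0.07 log units; within the scatter). That swap of fluoro for bromo stayed within the scatter. Among the measured compounds shown here, no measured step has methyl entering at this place, so the evidence is indirect. Compound 1 lacks the benzyl group altogether and gives no single-change comparison.

In this assay, no change beyond the scatter is therefore expected. The estimated step is a 1.1-fold lower number from compound 2 to compound 4 (0.03 log units; within the scatter). For compound 4 the expected value is 120000 nM, with an estimated range of 55000 nM to 220000 nM.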

Compound 4, half-maximal cytotoxic concentration: 12000 nM
Estimate against measurement, compound 4: 10-fold (1.00 log units) above, outside the stated range (below it).
By their numbers in this assay, from the lowest: compound 4; then compound 1; then compounds 2 and 3 (each within the scatter of the next).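

In this assay, the group at this place is not a matter of indifference: the series shows an 11-fold lower number from compound 2 to compound 4 (1.03 log units; beyond the scatter) and also a 13-fold lower number from compound 3 to compound 4 (1.10 log units; beyond the scatter) when methyl enters, while the exchange between the two halogens gave only a 1.2-fold higher number from compound 2 to compound 3 (0.07 log units; within the scatter) and stayed within the scatter. The two halogen compounds therefore stand together and the methyl compound stands apart, toward higher toxicity in this test, even though bromo and methyl each count as a single heavy atom, so that heavy-atom count alone does not predict the read-out at this place. Nothing measured on these compounds accounts for the drop, and its origin stays unassigned.

Still open, going by these compounds, is whether the drop belongs to methyl alone or also appears with a longer chain such as ethyl, with methoxy or with an amine on the same aromatic carbon. Also open, on these data alone, is where the unsubstituted benzyl group falls, whether with the two halogen compounds or with compound 4, which would show whether methyl lowers the number or the halogens raise it.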